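Swapping a chlorophenyl sulfone for a dimethoxyphenyl sulfone

The source may report more compounds than this note shows. Statements on the series, on what has been measured and on what is new or still open speak of the compounds shown alone.

Measured in an assay on isolated protein for displacement of a labelled ligand from metabotropic glutamate receptor 5 (Homo sapiens), with a stated time of 60 min, tested at 1 uM; a lower number here means less inhibition, a higher number more inhibition at the concentration tested (going by the name of the read-out):
- compound 1, `CC1CCN(c2c(S(=O)(=O)c3cccc(Cl)c3)cnc3cc(Cl)ccc23)CC1`, gives 92%
- compound 2, `Cc1ccc(S(=O)(=O)c2cnc3ccc(C)cc3c2N2CCC(C)CC2)cc1`, gives 82%
- compound 3, `CC1CCN(c2c(S(=O)(=O)c3cccc(C#N)c3)cnc3ccc(Cl)cc23)CC1`, gives 90%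

Compound 1 shows the highest of the three numbers, yet its gaps to compound 3 and to compound 2 both lie within the usual scatter of this kind of measurement, so the three measured compounds cannot be ranked against one another. All three carry an aryl sulfone on the shared core, and all three give high inhibition.

Compound 4, `COc1ccc(S(=O)(=O)c2cnc3cc(Cl)ccc3c2N2CCC(C)CC2)cc1OC`, has not yet been measured. It differs from compound 1 in one place: 3,4-dimethoxyphenyl in place of 3-chlorophenyl on a sulfonyl sulfur. Among the compounds with values here, no measured pair shows this kind of change, so the size of its effect has to be guessed from the fact that the three measured aryl sulfones all sit high.

Compound 4 is expected to remain a clear binder, with a step of a number 17 percentage points lower from compound 1 to compound 4 (beyond the scatter) that is estimated to be a modest decrease, possibly just beyond the scatter. The estimated value for compound 4 is 75%, within a range from 50% to 92%.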

Compound 4, a percentage reported as inhibition, at one concentration (the size of the read-out at that concentration, not a potency): 93%
For compound 4 the middle estimate is 18 percentage points below the measured one, and the stated range ends below it.
By their numbers in this assay, from the lowest: compounds 2, 3, 1 and 4 (each within the scatter of the next, the first and the last beyond it).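

In this assay, putting 3,4-dimethoxyphenyl in place of 3-chlorophenyl on a sulfonyl sulfur gives a number 1 percentage points higher from compound 1 to compound 4 (within the scatter), so compound 1 and compound 4 cannot be told apart. Within the data shown here, this is the first pair that isolates a change at this position, and it shows that the read-out stays high with 10 heavy atoms in the group instead of 7, and with 2 hydrogen-bond acceptors instead of 0. Nothing measured here explains this result.

As far as these compounds go, whether a group without an aromatic ring, such as methyl or cyclohexyl, would keep the read-out this high on the sulfonyl sulfur remains open. A percentage at one concentration also leaves open how the potencies of compound 1 and compound 4 compare.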